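The source may hold more compounds than are shown below. What is called first, only, known or untested is meant among the compounds shown, and "the series" means these compounds.

Working notes on the series. Compound 1 `Oc1ccc(-c2nc3cc(C(F)(F)F)ccc3[nH]2)cc1` has been run in an ADME assay on Vero cells (Chlorocebus sabaeus) for cytotoxicity (a lower number here means that less compound is tolerated, a higher number that more compound is tolerated), and returns only a limit: compound 1 gives > 100000 nM, which is a limit of the assay and not a number. Compound 2 `C#C[C@@]1(O)[C@H](O)[C@@H](CO)O[C@H]1n1ccc(N)nc1=O` likewise sits at a limit; in this assay compound 2 gives > 100000 nM. Going by the values given here, both values rest on (the limit of > 100000 nM in this assay, at which 2 of the 2 values shown sit), so no number is known for compound 1 and no step between measured compounds can be drawn. Compound 3 `COc1ccc(-c2nc3cc(C(F)(F)F)ccc3[nH]2)cc1` is not yet measured in this assay. It differs from compound 1 by methyl in place of hydrogen on an oxygen on an aromatic ring. With compound 1 at a limit, no direction can be read from the measured pair for this change. The step is expected to be a number no higher from compound 1 to compound 3 (the limit leaves the size open), none beyond the scatter. For compound 3 the estimate in this assay is 100000 nM, with a range of 40000 nM to 250000 nM, most probably reported again only as a limit.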

Compound 3, half-maximal cytotoxic concentration: 15000 nM
Beside the measured number, compound 3's estimate is 6.7-fold (0.82 log units) above it; the measured number lies below the stated range.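

At this oxygen on an aromatic ring, this assay now gives the series its first direction: going from hydroxy to methoxy brings an at least 6.6-fold lower number from compound 1 to compound 3 (0.82 log units; beyond the scatter). Compound 3 is the only compound shown with a number instead of a limit, so this position is not indifferent to substitution, and a single methyl in place of hydrogen is enough to make the core less tolerated. The full size of the step stays unknown because the value of compound 1 is only a limit: the limit of > 100000 nM in this assay, at which 2 of the 3 values shown sit.

The compounds shown do not separate the gain of the methyl from the loss of the hydroxy hydrogen. From the compounds shown here alone, it also remains open how a longer chain such as ethoxy, or an amine in place of the hydroxy, would read at this place.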